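Acid dissociation across two related cores

The source may report more compounds than this note shows. Statements on the series, on what has been measured and on what is new or still open speak of the compounds shown alone.

Measured so far:
- compound 1 `COc1ccc(-c2c(C)nc3c(NCc4cccnc4)cc(C)cn23)cc1OC`: 6.5
- compound 2 `COc1ccc(-c2c(C)nc3c(NCC4CCOCC4)cc(C)cn23)cc1OC`: 6.7
- compound 3 `COc1ccc(-c2c(C)nn3c(NCc4cccnc4)cc(C)nc23)cc1OC`: 5.4

All three numbers come from a physicochemical assay for acid dissociation. Within the core of compound 1, the exchange oxan-4-yl in place of pyridin-3-yl on a saturated chain carbon bound to a nitrogen on an aromatic ring gives a number 0.20 log units higher from compound 1 to compound 2 (within the scatter); the two values of compound 1 and compound 2 are therefore not distinguished by this assay. Compound 3 carries a different core, and how the two cores differ is not broken down here. Compound 3 sits lowest of the three, with compound 1 nearest and compound 2 furthest, both of those gaps beyond the scatter.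

Compound 4 `COc1ccc(-c2c(C)nn3c(NCC4CCOCC4)cc(C)nc23)cc1OC` is the counterpart of compound 2 on the core of compound 3. It differs from compound 3 by oxan-4-yl in place of pyridin-3-yl on a saturated chain carbon bound to a nitrogen on an aromatic ring, the same change already seen from compound 1 to compound 2, at the same place. Since that earlier step stayed within the scatter, the expectation for compound 4 rests on carrying the same small movement over to the lower-lying core, and the expected step is a number 0.20 log units higher from compound 3 to compound 4 (within the scatter). On that basis compound 4 is estimated at 5.6 in this assay, with an expected range from 5.2 to 6. Going by the values given here, the estimate assumes the two cores respond alike to this exchange, which only one measured pair supports.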

Compound 4, acid dissociation constant: 5.7
Beside the measured number, compound 4's estimate is 0.10 log units below it, within the range that was stated.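

In this assay, oxan-4-yl in place of pyridin-3-yl gives a number 0.20 log units higher from compound 1 to compound 2 (within the scatter) on the first core and a number 0.30 log units higher from compound 3 to compound 4 (within the scatter) on the second, so in both pairs the step stays within the scatter. This shows that, for these two pairs, the exchange carries from one core to the other without producing a step beyond the scatter; it does not show that the exchange moves the number at all, that the two cores respond identically, or that the agreement would hold for any other exchange or core. Nothing available here bears on why the exchange leaves the number within the scatter on both cores.

The compounds shown leave open whether the same holds when a group of a different kind enters at this place, such as piperidin-4-yl, which brings a ring amine, or a carboxylic acid on the saturated chain carbon bound to a nitrogen on an aromatic ring. They also leave open whether a longer chain in place of the methyl link in (oxan-4-yl)methyl would stay within the scatter on either core, and whether a third core would follow these two pairs.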